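Same aryl swap, tried on a methylated core

A few compounds are considered here, and "the series" means these few. Any claim that something is new, unique, unknown or untested is made for them only; others in the source may bear on it.

Compound 1 `CCS[C@@H]1[C@H](SCC)[C@@H](Cn2cc(-c3ccc(OC)cc3)nn2)O[C@H]1n1ccc(=O)[nH]c1=O` gives 16800 nM in a functional assay on A549 cells (Homo sapiens) for cytotoxicity, read by MTT assay, with a stated time of 72 h; a lower number here means that less compound is needed, a higher number that more compound is needed for the effect.
Compound 2 `CCS[C@@H]1[C@H](SCC)[C@@H](Cn2cc(-c3ccccc3C(F)(F)F)nn2)O[C@H]1n1ccc(=O)[nH]c1=O` gives 19400 nM in this assay.
Compound 3 `CCS[C@@H]1[C@H](SCC)[C@@H](Cn2cc(-c3ccc(OC)cc3)nn2)O[C@H]1n1cc(C)c(=O)[nH]c1=O` gives 38800 nM in this assay.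

Two changes have been made on the core of compound 1. Compound 2 carries 2-(trifluoromethyl)phenyl in place of 4-methoxyphenyl on an aromatic carbon, and this gave a 1.2-fold higher number from compound 1 to compound 2 (0.06 log units; within the scatter). Compound 3 differs in the core itself: methyl in place of hydrogen on an aromatic carbon, and this gave a 2.3-fold higher number from compound 1 to compound 3 (0.36 log units; beyond the scatter). The values of compound 2 and compound 3 lie within the scatter of each other, so nothing separates them.

Compound 4 `CCS[C@@H]1[C@H](SCC)[C@@H](Cn2cc(-c3ccccc3C(F)(F)F)nn2)O[C@H]1n1cc(C)c(=O)[nH]c1=O` has not yet been measured in this assay. It differs from compound 3 by 2-(trifluoromethyl)phenyl in place of 4-methoxyphenyl on an aromatic carbon, the same change as from compound 1 to compound 2, at a place described in identical words; compound 4 stands to compound 2 as compound 3 stands to compound 1, the two cores differing as told above.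

The step from compound 3 to compound 4 is expected to be a 1.2-fold higher number from compound 3 to compound 4 (0.07 log units; within the scatter) because a 1.2-fold higher number from compound 1 to compound 2 (0.06 log units; within the scatter) came from this very change and stayed within the scatter. That rests on a single earlier pair, so the expectation is loose. Compound 4 is therefore estimated at 46000 nM in this assay, with a likely range from 20000 nM to 100000 nM.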

Compound 4, half-maximal effective concentration: 7230 nM
Compound 4: the middle estimate sits 6.4-fold (0.80 log units) above what was measured; measured number below the stated range.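

On the core that carries the extra methyl, replacing 4-methoxyphenyl with 2-(trifluoromethyl)phenyl gave a 5.4-fold lower number from compound 3 to compound 4 (0.73 log units; beyond the scatter), so in this assay this change did not carry over unaltered from the core of compound 1: the same change on two cores in this assay, a 1.2-fold higher number (0.06 log units; within the scatter) from compound 1 to compound 2 and a 5.4-fold lower number (0.73 log units; beyond the scatter) from compound 3 to compound 4, 6.2-fold (0.79 log units) apart, beyond the scatter of two such steps

The same finding appears when the pairs are read the other way, with methyl in place of hydrogen on the core giving a 2.7-fold lower number from compound 2 to compound 4 (0.43 log units; beyond the scatter), whereas this change raised the number when 4-methoxyphenyl was present: the same change on two cores in this assay, a 2.3-fold higher number (0.36 log units; beyond the scatter) from compound 1 to compound 3 and a 2.7-fold lower number (0.43 log units; beyond the scatter) from compound 2 to compound 4, 6.2-fold (0.79 log units) apart, beyond the scatter of two such steps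

These steps show that, in this small set, the two changes do not simply add up and the result of each depends on the other, but they rest on just two cores and two aryl groups, so they neither explain the interaction nor predict how any other group would behave.

Going by these compounds, it remains open whether a similar dependence on the core would appear with a different substituent on the phenyl ring, such as a nitrile or an amine. On these data alone, it is also open what a longer chain, such as an ethyl group in place of the core methyl, would do with either aryl group.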